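Benzoxazole sulfonamides: tolerance in a human kidney cell assay

The compounds below may be only part of what the source reports. "The series", "measured", "known", "first", "only" and "open" are said of these compounds alone.

Measured so far:
compound 1, `O=S(=O)(Nc1ccc(-c2nc3ccccc3o2)cc1)c1ccc(F)c(C(F)(F)F)c1`: 82000 nM
compound 2, `Cc1ccccc1S(=O)(=O)Nc1ccc2oc(-c3ccccc3)nc2c1`: 57000 nM
compound 3, `O=S(=O)(Nc1ccc(-c2nc3ccccc3o2)cc1)c1cccc(O)c1`: limit, > 100000 nM

The series shares a benzoxazole bearing an aryl sulfonamide. In an ADME assay on HEK293 cells (Homo sapiens) for cytotoxicity, read by resazurin assay, with a stated time of 48 h (a higher number here means that more compound is tolerated, a lower number that less compound is tolerated), compound 1 gives 82000 nM and compound 2 gives 57000 nM. For compound 3 this assay reports only a limit, > 100000 nM, and that is one of the three values shown (the limit of > 100000 nM in this assay, at which 1 of the 3 values shown sits). Of the two numbers given, compound 2 carries the one at the lower end, but compound 1 sits within the scatter of it, so the two are not told apart. No step between two measured compounds that differ in one place is shown, so there is nothing to calibrate the next change against.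

Compound 4, `O=S(=O)(Nc1ccc2oc(-c3ccccc3)nc2c1)c1cccc(F)c1`, is not yet measured in this assay. It differs from compound 2 as follows: 3-fluorophenyl in place of 2-methylphenyl on a sulfonyl sulfur. The change swaps one small aryl group for another of the same size on the sulfonyl sulfur.

Given that compound 1 and compound 2 sit within the scatter of each other, compound 4 is expected to give a number close to that of compound 2, estimated at 70000 nM, with a range of 30000 nM to 150000 nM. The expected step of a 1.2-fold higher number from compound 2 to compound 4 (0.09 log units; within the scatter) is estimated to lie within the scatter, with no direction claimed.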

Compound 4, half-maximal cytotoxic concentration: 68000 nM
Compound 4: the middle estimate sits 1.0-fold (0.01 log units) above what was measured, within the range that was stated.
By their numbers in this assay, from the lowest: compounds 2, 4 and 1 (each within the scatter of the next). At a limit, above all of these: compound 3.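

In this assay, the series now has its first step between two measured compounds that differ in one place: a 1.2-fold higher number from compound 2 to compound 4 (0.08 log units; within the scatter), with 3-fluorophenyl in place of 2-methylphenyl on a sulfonyl sulfur. Among the compounds shown here, both groups are a six-membered aromatic ring of carbon only with no net charge, and this exchange on the sulfonyl sulfur does not tell compound 2 and compound 4 apart, which gives a first yardstick for changes of this kind at this position. No measurement shown here bears on why the step is this size.

For the compounds shown here, one step covers only this pair of aryl groups, so it remains open whether something different in kind on the sulfonyl sulfur, such as an aryl ring carrying an amine or a carboxylic acid, or a longer chain in place of the aryl ring, would give a step beyond the scatter. Compound 3 gives only a limit, > 100000 nM, so it provides no number to set against this step.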